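A Benzyl Swap Starting from Compound 3

The source may hold more compounds than are shown below. What is called first, only, known or untested is meant among the compounds shown, and "the series" means these compounds.

Compound 1 `C[C@@H](Nc1c(C(=O)NCc2ccc(F)cc2)nc(Br)c2cccnc12)c1ccccc1` reads > 20000 nM in a functional assay on HCT-116 cells (Homo sapiens) for cytotoxicity, read by MTT assay, with a stated time of 72 h (a higher number here means a weaker inhibitor, a lower number a stronger inhibitor), and that value is a limit of the assay, not a number. Compound 2 `Nc1ccc(Nc2c(C(=O)NCc3ccc(F)cc3)nc(Br)c3cccnc23)cc1` gives 10000 nM. For the measured compounds named here, the only measured step, an at least 2.0-fold lower number from compound 1 to compound 2 (0.30 log units; that floor lies within the scatter), changes a group on a nitrogen on an aromatic ring. Compound 3 `COc1cccc(CNC(=O)c2nc(Br)c3cccnc3c2N[C@H]2CC[C@H](N)CC2)c1` gives 6000 nM, which lies within the scatter of the value for compound 2. Compound 4 `N[C@H]1CC[C@H](Nc2c(C(=O)NCc3ccc(Cl)cc3Cl)nc(Br)c3cccnc23)CC1` differs from it as follows: 2,4-dichlorophenyl in place of 3-methoxyphenyl on a saturated chain carbon bound to an amide-type nitrogen. In short, 2,4-dichlorophenyl replaces 3-methoxyphenyl on a saturated chain carbon bound to an amide-type nitrogen. Going by the values given here, no measured step touches this place, so the guide remains compound 3 at 6000 nM, and no step beyond the scatter is expected. The expected change is a 1.2-fold lower number from compound 3 to compound 4 (0.08 log units; within the scatter). For compound 4 the estimate is 5000 nM, with an expected range from 1500 nM to 16000 nM.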

Compound 4, half-maximal inhibitory concentration: 6000 nM
For compound 4 the middle estimate is 1.2-fold (0.08 log units) below the measured one, and the stated range covers the measured number.
By their numbers in this assay, from the lowest: compounds 3, 4 and 2 (each within the scatter of the next). At a limit, above all of these: compound 1.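

For the compounds shown here, this is the first measured step at the place on a saturated chain carbon bound to an amide-type nitrogen, and in this assay putting 2,4-dichlorophenyl in place of 3-methoxyphenyl gives no change at the digits printed from compound 3 to compound 4 (within the scatter). Here, two chlorine atoms instead of the methoxy group leave the reading unmoved, so this swap separates neither compound. Nothing measured here accounts for this result.

Open, from the compounds shown here alone, is whether a ring carrying an amine or a carboxylic acid would read the same at this place. A longer chain there is equally untested by these compounds.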